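From Diethylamino to 1,1-Dioxo-1,3-thiazolidin-3-yl: a Clearance Estimate

The source may hold more compounds than are shown below. What is called first, only, known or untested is meant among the compounds shown, and "the series" means these compounds.

Three compounds have been measured in an ADME assay on microsomes from liver (Mus musculus) for metabolic stability, read by LC-MS, using NADPH, with a stated time of 45 min, tested at 0.5 uM; a higher number here means faster removal of the compound, a lower number slower removal:
compound 1 `O=C(CCSc1nc2cc(Cl)ccc2o1)N1CCC1` gives 17.9 mL/min/g
compound 2 `CCN(CC)C(=O)CCSc1nc2cc(Cl)ccc2o1` gives 108 mL/min/g
compound 3 `O=C(CCSc1nc2ccc(Cl)cc2o1)N1CCCC1` gives 109 mL/min/g

For the measured compounds named here, compound 2 holds the second highest of these three numbers; compound 3 sits within the scatter of it, while compound 1 lies lower, the step of a 6.0-fold higher number from compound 1 to compound 2 (0.78 log units; beyond the scatter) being the only one between compounds that differ in a single place. Compound 4 `O=C(CCSc1nc2cc(Cl)ccc2o1)N1CCS(=O)(=O)C1` is the next question, with 1,1-dioxo-1,3-thiazolidin-3-yl in place of diethylamino on a carbonyl carbon. Going by the values given here, the one measured step concerns a swap of groups on the same carbonyl carbon and was modest; no measured pair carries a ring with hetero atoms in that place. Compound 4 is therefore expected to show a step of a 2.0-fold lower number from compound 2 to compound 4 (0.29 log units; within the scatter) in this assay, with wide uncertainty. The estimate for compound 4 is 55 mL/min/g, between 20 mL/min/g and 150 mL/min/g.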

Compound 4, intrinsic clearance in a liver preparation (reported as CLH), per the amount of preparation that the assay uses: 8.9 mL/min/g
Estimate against measurement, compound 4: 6.2-fold (0.79 log units) above; measured number below the stated range.
By their numbers in this assay, from the lowest: compounds 4 and 1 (each within the scatter of the next); then compounds 2 and 3 (each within the scatter of the next).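

In this assay, 1,1-dioxo-1,3-thiazolidin-3-yl on this carbonyl carbon, the first ring with hetero atoms measured there, gives a 12-fold lower number from compound 2 to compound 4 (1.08 log units; beyond the scatter). Set against azetidin-1-yl at the same place, it gives a 2.0-fold lower number from compound 1 to compound 4 (0.30 log units; within the scatter), so the two rings are not told apart here, while diethylamino stands clear of both. Nothing shown gives a reason for either step. The compounds shown leave open whether a morpholine or piperidine ring on this carbonyl carbon would stay with these two rings or go with diethylamino.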